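The source may hold more compounds than are shown below. What is called first, only, known or untested is meant among the compounds shown, and "the series" means these compounds.

In a functional assay on SW-620 cells (Homo sapiens) for cytotoxicity (on this read-out lower numbers stand for stronger inhibition and higher numbers for weaker inhibition), compound 1 `COc1ccc2nc(NC(=O)CCCCC(=O)NO)sc2c1` gives 9.07 ug/mL, the highest number of the three measured, against compound 2 `O=C(CCCCCCC(=O)Nc1nc2ccccc2s1)NO` at 4.01 ug/mL and compound 3 `Cc1ccc2nc(NC(=O)CCCCCCC(=O)NO)sc2c1` at 0.56 ug/mL. Compound 4 `O=C(CCCCC(=O)Nc1nc2ccc([N+](=O)[O-])cc2s1)NO` has nitro in place of methoxy on an aromatic carbon of compound 1: nitro in place of methoxy on an aromatic carbon. Going by the values given here, only one measured step concerns a substituent at an aromatic carbon, a 7.2-fold lower number from compound 2 to compound 3 (0.85 log units; beyond the scatter), modest and beyond the scatter. Among the compounds with values here, that step is methyl in place of hydrogen, on a chain that differs from the one in compound 1, so it gives no direction here. Within the data shown here, no measured step exchanges methoxy or nitro. The expected change, a 1.3-fold lower number from compound 1 to compound 4 (0.11 log units; within the scatter), is therefore none beyond the scatter. For compound 4 the estimate is 7 ug/mL, with an expected range of 2.5 ug/mL to 20 ug/mL.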

Compound 4, half-maximal inhibitory concentration: > 30 ug/mL
Compound 4 ended at the assay's limit; the forecaster's own chance of this, stated with the estimate: 5%; middle value at least 4.2-fold (0.63 log units) away from the limit.
By their numbers in this assay, from the lowest: compound 3; then compound 2; then compound 1. At a limit, above all of these: compound 4.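

In this assay, exchanging the group at this aromatic carbon of the core of compound 1 moves the read-out beyond the scatter: an at least 3.3-fold higher number from compound 1 to compound 4 (0.51 log units; beyond the scatter). Compound 4 stands at a limit and not at a number, so this step gives only a lower bound: the limit of > 30 ug/mL in this assay, at which 1 of the 4 values shown sits. The position is therefore sensitive on the chain of compound 1, which the methyl step on the other chain could not show.

On these data alone, how far compound 4 lies past the limit remains open, as does whether losing methoxy or gaining nitro drives the step. An amine at this carbon, or nitro on a longer chain, would help separate these.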